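The source may report more compounds than this note shows. Statements on the series, on what has been measured and on what is new or still open speak of the compounds shown alone.

Within the data shown here, in a functional assay on HeLa cells (Homo sapiens) for cytotoxicity, read by MTT assay, with a stated time of 48 h (a lower number here means a stronger inhibitor, a higher number a weaker inhibitor), compound 1 (`O=C(O)CN1C(=O)/C(=C/c2nc3ccccc3n2Cc2ccc(C(F)(F)F)cc2)SC1=S`) gives 21400 nM, and compound 2 (`O=C(O)CN1C(=O)/C(=C/c2nc3ccccc3n2Cc2ccccc2F)SC1=S`) gives 640 nM, the lower of the two numbers so far. Compound 3 (`COc1ccc2nc(/C=C3\SC(=S)N(CC(=O)O)C3=O)n(Cc3ccccc3F)c2c1`) differs from compound 2 by methoxy in place of hydrogen on an aromatic carbon. Among the measured compounds shown here, only one measured step is available, a 33-fold lower number from compound 1 to compound 2 (1.52 log units; beyond the scatter), which is large and beyond the scatter, but it lies elsewhere in the molecule and bears on this change only indirectly. For the measured compounds named here, no measured compound carries a group at this aromatic carbon, so the expectation stays close to compound 2 at 640 nM, with no step beyond the scatter expected in this assay, in either direction. The expected change is a 1.3-fold higher number from compound 2 to compound 3 (0.10 log units; within the scatter). For compound 3 the estimated value is 800 nM, with an expected range from 200 nM to 3500 nM.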

Compound 3, half-maximal inhibitory concentration: 28100 nM
For compound 3 the middle estimate is 35-fold (1.55 log units) below the measured one; measured number outside the range, above it.
By their numbers in this assay, from the lowest: compound 2; then compounds 1 and 3 (each within the scatter of the next).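

In this assay, among these compounds, methoxy in place of hydrogen on this aromatic carbon brings a 44-fold higher number from compound 2 to compound 3 (1.64 log units; beyond the scatter), so a position on which the earlier compounds gave no information turns out to matter greatly for this read-out. The step is large, like a 33-fold lower number from compound 1 to compound 2 (1.52 log units; beyond the scatter), which means that this small group of 2 heavy atoms on the six-membered aromatic ring counts for as much here as the exchange of 4-(trifluoromethyl)phenyl for 2-fluorophenyl. Nothing available explains why this change has so large an effect. The compounds shown leave open whether a hydroxyl, a fluorine or an amine on this aromatic carbon would give a step of similar size, or whether the step is tied to methoxy. They also leave open whether methoxy here would act the same way alongside 4-(trifluoromethyl)phenyl.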